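The source may hold more compounds than are shown below. What is called first, only, known or untested is meant among the compounds shown, and "the series" means these compounds.

Measured so far:
Compound 1, `O=C(CSc1nnc(-c2ccncc2)o1)N/N=C/c1ccc(Br)cc1`, in a functional assay on MCF7 cells (Homo sapiens) for cytotoxicity, read by MTT assay, with a stated time of 48 h (on this read-out lower numbers stand for stronger inhibition and higher numbers for weaker inhibition), gives 19100 nM.
Compound 2, `O=C(CSc1nnc(-c2ccncc2)o1)N/N=C/c1cccc(F)c1`, in this assay gives 24900 nM.

Compound 2 holds the highest of these two numbers, and the step of a 1.3-fold higher number from compound 1 to compound 2 (0.12 log units; within the scatter) stays within the scatter. Compound 3, `O=C(CSc1nnc(-c2ccncc2)o1)N/N=C/c1cc(Br)ccc1O`, carries the change (5-bromo-2-hydroxyphenyl in place of 3-fluorophenyl on a carbon with a double bond to nitrogen). Going by the values given here, no measured step covers this exchange; the only step available, from one halogen-bearing phenyl to another, was within the scatter, so in this assay compound 3 is expected to show no step beyond the scatter, namely a 1.2-fold lower number from compound 2 to compound 3 (0.10 log units; within the scatter). Compound 3 is therefore estimated at 20000 nM, with a range from 6000 nM to 60000 nM.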

Compound 3, half-maximal inhibitory concentration: 7770 nM
Beside the measured number, compound 3's estimate is 2.6-fold (0.41 log units) above it, within the range that was stated.
By their numbers in this assay, from the lowest: compound 3; then compounds 1 and 2 (each within the scatter of the next).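

In this assay, the place on a carbon with a double bond to nitrogen now shows a change beyond the scatter, which the step between the two halogen-bearing phenyl groups did not show. The 5-bromo-2-hydroxyphenyl group gives stronger inhibition than 3-fluorophenyl (a 3.2-fold lower number from compound 2 to compound 3 (0.51 log units; beyond the scatter)) and than 4-bromophenyl (a 2.5-fold lower number from compound 1 to compound 3 (0.39 log units; beyond the scatter)). No measurement on hand explains why this group gives the lower number.

The compounds shown leave open whether the hydroxy or the bromo part of this group carries the change. They also leave open how an amine or a carboxylic acid would fare at this place.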